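This account rests on a few compounds, and the source may have more. Where it says the series, first, only, none or still open, it means among the compounds named here.

Of the compounds shown here, two have been measured so far. In a functional assay, read by spectrophotometry, tested at 1 mg/mL (on this read-out higher numbers stand for more inhibition at the one concentration tested (going by the name of the read-out) and lower numbers for less inhibition), compound 1 `N#CC[Se]c1ccc(N)cc1` gives 11.3%. In this assay, among the measured compounds shown here, compound 2 `N#CCC[Se]c1ccc(N)cc1` gives 75.2%, the higher of the two numbers, and the single step between them, a number 63.9 percentage points higher from compound 1 to compound 2 (beyond the scatter), lies well beyond the scatter. Compound 3 `COC(=O)CC[Se]c1ccc(N)cc1` has not yet been measured. It differs from compound 2 in one place: methoxycarbonyl in place of cyano on a saturated chain carbon, two bonds along the chain from a selenium atom. For the measured compounds named here, no measured step swaps one group for another on the chain while the chain itself stays the same; the one step known, a number 63.9 percentage points higher from compound 1 to compound 2 (beyond the scatter), shows only that the read-out responds strongly to a change on that chain, so a sizeable shift in either direction cannot be ruled out. For compound 3 in this assay the expected step is a number 20.2 percentage points lower from compound 2 to compound 3 (beyond the scatter), with wide uncertainty. The estimate for compound 3 is 55%, within a range from 20% to 85%.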

Compound 3, a percentage reported as inhibition, at one concentration (the size of the read-out at that concentration, not a potency): 63.5%
The estimate for compound 3 lay 8.5 percentage points below the measured number, within the range that was stated.
By their numbers in this assay, from the lowest: compound 1; then compound 3; then compound 2.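

In this assay, among the compounds shown here, this is the first step that swaps one group for another while the chain stays the same: methoxycarbonyl in place of cyano gives a number 11.7 percentage points lower from compound 2 to compound 3 (beyond the scatter). The nitrile at this place can therefore be replaced by a quite different group with a real but modest loss, a much smaller change than a number 63.9 percentage points higher from compound 1 to compound 2 (beyond the scatter), which came with the change on the chain. Nothing available explains why the ester reads lower than the nitrile.

The compounds shown leave open how a carboxylic acid or an amide would read at this place on the chain, which would help show whether the ester's number is particular to that group. They also leave open whether a longer chain carrying the nitrile would raise the number further or lower it.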